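Swapping trifluoromethyl for cyano on the aryl ring of compound 1

A few compounds are considered here, and "the series" means these few. Any claim that something is new, unique, unknown or untested is made for them only; others in the source may bear on it.

Compound 1 `CC1=C(/C=C/C(=O)/C=C/c2cccc(C(F)(F)F)c2)C(C)(C)CCC1O` is one of three close analogues sharing a core and tested in a functional assay on CWR22R cells (Homo sapiens) for cytotoxicity, read by MTT assay, with a stated time of 72 h (a lower number here means a stronger inhibitor, a higher number a weaker inhibitor), where compound 1 gives 1700 nM. Compound 2 `CC1=C(/C=C/C(=O)/C=C/c2cc(C(F)(F)F)cc(C(F)(F)F)c2)C(C)(C)CCC1O` gives 2200 nM and compound 3 `CC1=C(/C=C/C(=O)/C=C/c2cc(C(F)(F)F)ccc2F)C(C)(C)CCC1O` gives 2000 nM. Compound 1 has the lowest number of the three, but both of its neighbours sit within the scatter: a 1.3-fold higher number from compound 1 to compound 2 (0.11 log units; within the scatter) and a 1.2-fold higher number from compound 1 to compound 3 (0.07 log units; within the scatter). Compound 4 `CC1=C(/C=C/C(=O)/C=C/c2cccc(C#N)c2)C(C)(C)CCC1O` differs from compound 1 by cyano in place of trifluoromethyl on an aromatic carbon, the cyano sitting meta to a large group. Neither measured step bears directly on this exchange: each adds a group elsewhere on the ring while the trifluoromethyl stays in place, and each stays within the scatter. The three numbers together suggest that this ring tolerates changes in its substituents without a step beyond the scatter, so a similar outcome is expected here, with a slight lean towards a higher number, the expected step being a 1.4-fold higher number from compound 1 to compound 4 (0.13 log units; within the scatter). Compound 4 is therefore estimated at 2300 nM in this assay, in a range from 900 nM to 6000 nM.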

Compound 4, half-maximal inhibitory concentration: 2200 nM
Compound 4: middle estimate off by 1.0-fold (0.02 log units), on the high side, and the stated range covers the measured number.
By their numbers in this assay, from the lowest: compounds 1, 3, 2 and 4 (each within the scatter of the next).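

Where the earlier steps added a group while the trifluoromethyl stayed in place, this step replaces the trifluoromethyl itself, and in this assay cyano in its place gives a 1.3-fold higher number from compound 1 to compound 4 (0.11 log units; within the scatter). The trifluoromethyl on this aromatic carbon, meta to a large group, can therefore be exchanged for a cyano with fewer heavy atoms and a hydrogen-bond acceptor, without a step beyond the scatter. Nothing shown here offers an explanation for this outcome.

All the steps shown stay within the scatter, so they mark no limit to what this position accepts. As far as these compounds go, it remains open whether an amine, a carboxylic acid or a longer alkyl chain on this carbon would give a step beyond the scatter.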